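Fluoro in place of hexyloxy at the ortho position of compound 2

The compounds below may be only part of what the source reports. "The series", "measured", "known", "first", "only" and "open" are said of these compounds alone.

Three compounds share one core and differ only in the group on one aromatic carbon: compound 1 `Nc1ncc(Cc2ccccc2I)c(N)n1`, compound 2 `CCCCCCOc1ccccc1Cc1cnc(N)nc1N` and compound 3 `COCc1ccccc1Cc1cnc(N)nc1N`. In an assay for inhibition of Dihydrofolate reductase (Gallus gallus) (a higher number here means a weaker inhibitor, a lower number a stronger inhibitor), compound 2 gives 7940 nM, the lowest of the three; compound 1 gives 8710 nM and compound 3 gives 39800 nM. The step of a 1.1-fold lower number from compound 1 to compound 2 (0.04 log units; within the scatter) lies within the scatter, while a 5.0-fold higher number from compound 2 to compound 3 (0.70 log units; beyond the scatter) and a 4.6-fold higher number from compound 1 to compound 3 (0.66 log units; beyond the scatter) are modest rises.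

Compound 4 `Nc1ncc(Cc2ccccc2F)c(N)n1` is not yet measured. It differs from compound 2 in one place: fluoro in place of hexyloxy on an aromatic carbon. Among the measured compounds shown here, two measured steps bear on this. The step of a 5.0-fold higher number from compound 2 to compound 3 (0.70 log units; beyond the scatter) also removed hexyloxy and raised the number, whereas a 1.1-fold lower number from compound 1 to compound 2 (0.04 log units; within the scatter) shows that iodo and hexyloxy give similar numbers. Fluoro is neither iodo nor methoxymethyl, so the outcome is uncertain, but the removal of hexyloxy in this assay has so far given a weaker inhibitor. The expected step is therefore a modest rise, a 1.9-fold higher number from compound 2 to compound 4 (0.28 log units; within the scatter). Compound 4 is estimated at 15000 nM, with a range from 5000 nM to 50000 nM.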

Compound 4, inhibition constant: 43700 nM
The estimate for compound 4 lay 2.9-fold (0.46 log units) below the measured number, and the stated range covers the measured number.
By their numbers in this assay, from the lowest: compounds 2 and 1 (each within the scatter of the next); then compounds 3 and 4 (each within the scatter of the next).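

Fluoro on this aromatic carbon gives a 5.5-fold higher number from compound 2 to compound 4 (0.74 log units; beyond the scatter) and a 5.0-fold higher number from compound 1 to compound 4 (0.70 log units; beyond the scatter) in this assay, so it separates from both hexyloxy and iodo by a modest step. Against methoxymethyl, a 1.1-fold higher number from compound 3 to compound 4 (0.04 log units; within the scatter) shows no separation, so the four groups fall into two pairs: hexyloxy with iodo at the lower numbers, and methoxymethyl with fluoro at the higher ones. This split does not follow the change from 7 heavy atoms in hexyloxy to 1 in fluoro in any simple way, since iodo stays with hexyloxy, and nothing measured here offers an explanation for it.

The compounds shown leave open whether an amine, a carboxylic acid or a methoxy group on this carbon would join the first pair or the second. They also leave open whether an alkoxy chain longer than hexyloxy would lower the number further.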